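Sulfonyl ester versus hydroxyalkyl ether on the shared core

A few compounds are considered here, and "the series" means these few. Any claim that something is new, unique, unknown or untested is made for them only; others in the source may bear on it.

Two compounds of the series carry a measured value. In an assay on cells for binding affinity to vitamin D3 receptor (Homo sapiens), read by fluorescence, tested at 1 uM (on this read-out higher numbers stand for more inhibition at the one concentration tested (going by the name of the read-out) and lower numbers for less inhibition), compound 1 `CCC(CC)(c1ccc(OS(=O)(=O)c2ccc(C)cc2)c(C)c1)c1ccc(OCC(=O)C(C)(C)C)c(OCC(=O)C(C)(C)C)c1` gives 35%, while compound 2 `CCC(CC)(c1ccc(OCCCCCCCO)c(C)c1)c1ccc(OCC(O)C(C)(C)C)c(OCC(O)C(C)(C)C)c1` gives 5%, the lower of the two numbers and a gap beyond the usual scatter. Compound 3 `CCC(CC)(c1ccc(OS(=O)(=O)c2ccccc2)c(C)c1)c1ccc(OCC(O)C(C)(C)C)c(OCC(O)C(C)(C)C)c1` is not yet measured. It differs from compound 2 by phenylsulfonyl in place of 7-hydroxyheptyl on an oxygen on an aromatic ring. Within the data shown here, no step between measured compounds is available; given the value of compound 1 in this assay with its sulfonyl ester, an upward step of moderate size is expected, a number 20 percentage points higher from compound 2 to compound 3 (beyond the scatter). For compound 3 the expected value in this assay is 25%, within 5% to 45%.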

Compound 3, a percentage reported as inhibition, at one concentration (the size of the read-out at that concentration, not a potency): "not active" (no number reported)
Compound 3 has no reported number here; the estimate stays without a comparison.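

Among these compounds, compound 3 is reported without a number in this assay and no step from compound 2 can be read. From the compounds shown here alone, whether phenylsulfonyl in place of 7-hydroxyheptyl shifts this read-out stays open, and no supporting data bear on the result.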